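Ethoxy in Place of Benzylamino on a Carbonyl Carbon

The compounds below may be only part of what the source reports. "The series", "measured", "known", "first", "only" and "open" are said of these compounds alone.

Compound 1 `Nc1ncnc2c1nc(NCc1cccc(Cl)c1)n2[C@@H]1O[C@H](CO)[C@@H](O)[C@H]1O`: 5400 nM
Compound 2 `Nc1ncnc2c1ncn2[C@@H]1O[C@H](COC(=O)NCc2ccccc2)[C@@H](O)[C@H]1O`: > 100000 nM

In an assay on COS-7 cells for inhibition of sodium/nucleoside cotransporter 2 (Homo sapiens), read by scintillation counting, in the presence of a further agent that is not named here (a higher number here means a weaker inhibitor, a lower number a stronger inhibitor), compound 1 gives 5400 nM. For compound 2 the assay reports no number, only a limit, > 100000 nM. From the compounds shown here alone, compound 2 therefore stands at the limit of > 100000 nM in this assay, at which 1 of the 2 values shown sits, so its true potency is unknown beyond that. Compound 3 `CCOC(=O)OC[C@H]1O[C@@H](n2cnc3c(N)ncnc32)[C@H](O)[C@@H]1O` is not yet measured. It differs from compound 2 in a single spot: ethoxy in place of benzylamino on a carbonyl carbon. Within the data shown here, no measured pair here tells how much such a swap moves the read-out, and with compound 2 itself only a limit, the step from compound 2 to compound 3 cannot be sized from the data. The expected step that the limit leaves unreadable from compound 2 to compound 3 is none beyond the scatter, with compound 3 expected to stay at the limit as well. For compound 3 the estimate is 150000 nM, within 40000 nM to 500000 nM.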

Compound 3, half-maximal inhibitory concentration: > 100000 nM
Compound 3: only a limit was reported; the forecaster's own chance of this, stated with the estimate: 75%; the middle value does not contradict the limit.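

In this assay compound 3 also gives only a limit, > 100000 nM. Among these compounds, compound 2 has a limit as well, so no step between compound 2 and compound 3 can be read: the limit of > 100000 nM in this assay, at which 2 of the 3 values shown sit.

Left open is whether ethoxy and benzylamino on the carbonyl carbon differ in potency at all, and how far past that limit the true values of compound 2 and compound 3 lie.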